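This account rests on a few compounds, and the source may have more. Where it says the series, first, only, none or still open, it means among the compounds named here.

Two compounds of this series have been examined in a functional assay on Jurkat cells (Homo sapiens) for inhibition; on this read-out lower numbers stand for stronger inhibition and higher numbers for weaker inhibition. Compound 1 `CCOC(=O)c1cnc(N(Cc2ccccc2)N2C(=O)C=C(C)C2=O)nc1C(F)(F)F` gives 450 nM in this assay. Compound 2 `CCOC(=O)c1cnc(NN2C(=O)C=C(C)C2=O)nc1C` gives 1900 nM, which is the higher of the two numbers, and the gap between compound 2 and compound 1 lies beyond the usual scatter of this assay. Going by the values given here, compound 1 differs from compound 2 in more than one place, so their two values show only that compound 2 is the weaker inhibitor of the pair.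

Compound 3 `CCOC(=O)c1cnc(NN2C(=O)C=C(C)C2=O)nc1-c1nccs1` has not yet been measured. It differs from compound 2 in a single place: 1,3-thiazol-2-yl in place of methyl on an aromatic carbon. The new group sits on an aromatic carbon of the six-membered aromatic ring, ortho to an ethoxycarbonyl group. Among the compounds with values here, no measured pair shows the effect of this change on its own, so any expectation rests on the weak starting point of compound 2 alone. A modest step toward stronger inhibition, not far beyond the scatter, is expected: a 2.1-fold lower number from compound 2 to compound 3 (0.32 log units; beyond the scatter). Compound 3 is therefore estimated to give about 900 nM in this assay, within a range from 200 nM to 4000 nM.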

Compound 3, half-maximal inhibitory concentration: 2200 nM
Estimate against measurement, compound 3: 2.4-fold (0.39 log units) below; measured number inside the range.
By their numbers in this assay, from the lowest: compound 1; then compounds 2 and 3 (each within the scatter of the next).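

Replacing methyl with 1,3-thiazol-2-yl on this aromatic carbon, ortho to the ethoxycarbonyl group, gives a 1.2-fold higher number from compound 2 to compound 3 (0.06 log units; within the scatter) in this assay, so compound 2 and compound 3 cannot be told apart on this read-out. Going by these compounds alone, this is the first comparison that isolates a single place, and it shows that this position accommodates a five-membered aromatic ring with two hetero atoms in place of a single carbon without a difference beyond the scatter. The same comparison gives no sign that this exchange strengthens inhibition, and nothing available explains the outcome.

The compounds shown leave open whether an amine, a carboxylic acid or a longer alkyl chain at this position would also stay within the scatter of compound 2, as only methyl and 1,3-thiazol-2-yl can be compared here. As far as these compounds go, compound 1 carries trifluoromethyl at this position but differs from compound 2 and compound 3 in more than one place, so it remains open which of its differences bears on the value of compound 1, 450 nM, in this assay.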